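Lengthening the Chain on the Shared Core

The source may hold more compounds than are shown below. What is called first, only, known or untested is meant among the compounds shown, and "the series" means these compounds.

Measured compounds:
Compound 1, `Cc1nc2c(OCc3ccccc3)cccn2c1N`, in a functional assay on the whole organism with Rattus norvegicus as the target, at a dose of 40 mg/kg by the intraperitoneal route (on this read-out higher numbers stand for more inhibition at the one dose given (going by the name of the read-out) and lower numbers for less inhibition), gives 99%.
Compound 2, `CCc1nc2c(OCc3ccccc3)cccn2c1N`, in this assay gives 83%.

Going by the values given here, compound 2 stands lowest of the two numbers, with compound 1 the only neighbour, above it beyond the scatter. Compound 3, `CCCc1nc2c(OCc3ccccc3)cccn2c1N`, differs from compound 2 by methyl in place of hydrogen on a saturated chain carbon, two bonds along the chain from an aromatic carbon. Among the compounds with values here, the one measured step that bears on this, a number 16 percentage points lower from compound 1 to compound 2 (beyond the scatter), was modest. A further modest lowering, or no change beyond the scatter, is therefore expected, as a number 9 percentage points lower from compound 2 to compound 3 (within the scatter). Compound 3 is estimated at 74%, between 55% and 92%.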

Compound 3, a percentage reported as inhibition, in the whole organism at one dose (the size of the read-out at that dose, not a potency): 31%
Beside the measured number, compound 3's estimate is 43 percentage points above it; the measured number lies below the stated range.
By their numbers in this assay, from the lowest: compound 3; then compound 2; then compound 1.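

Lengthening the chain at this position does not lower the number in even steps: in this assay there is a number 52 percentage points lower from compound 2 to compound 3 (beyond the scatter), far larger than the modest a number 16 percentage points lower from compound 1 to compound 2 (beyond the scatter) before it. Read as a single change, ethyl in place of hydrogen on the chain carbon bound to an aromatic carbon gives a number 68 percentage points lower from compound 1 to compound 3 (beyond the scatter), and most of that loss comes with the last methyl. No measurement at hand explains why the fall steepens at propyl.

From the compounds shown here alone, whether a butyl chain would fall further remains open. So does how a branched isopropyl group or a chain ending in an amine would compare with propyl.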